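Swapping a fluorophenyl for a bromo-methylphenyl on the core

The compounds below may be only part of what the source reports. "The series", "measured", "known", "first", "only" and "open" are said of these compounds alone.

Of the compounds shown here, three sharing one core have been tested in a toxicity assay on A549 cells (Homo sapiens) for cytotoxicity, read by luminescence and CellTiter-Glo, with a stated time of 48 h; on this read-out higher numbers stand for lower toxicity in this test and lower numbers for higher toxicity in this test. Compound 1 `CCCCOc1ccc(-c2nc3ncccn3c2NC(C)C)cc1` gives 68000 nM. Compound 2 `O=C(O)CCCOc1ccc(-c2nc3ncccn3c2NC2CCCCC2)cc1` returns only > 100000 nM, which is a limit of the assay rather than a number. Compound 3 `Fc1ccc(-c2nc3ncccn3c2NC2CCCCC2)cc1` gives 100000 nM. Compound 3 and compound 1 thus sit within the usual scatter of each other, so nothing separates them on these numbers.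

Going by the values given here, the one measured step that touches the same part of the molecule is the change a number no higher from compound 2 to compound 3 (the limit leaves the size open). Its size cannot be read, because the limit of > 100000 nM in this assay, at which 1 of the 3 values shown sits, hides where compound 2 truly lies. It only tells that putting a small halogen on the aromatic ring did not raise the number.

Compound 4 `Cc1cc(Br)ccc1-c1nc2ncccn2c1NC1CCCCC1` has not been measured. It differs from compound 3 by 4-bromo-2-methylphenyl in place of 4-fluorophenyl on an aromatic carbon. Among the compounds with values here, with no step of known size to lean on, the safest guide is compound 3 itself at 100000 nM, allowing some drift toward somewhat higher toxicity in this test because the change a number no higher from compound 2 to compound 3 (the limit leaves the size open) offers no sign that a halogen on this ring lowers toxicity. In this assay compound 4 is therefore expected to give about 60000 nM, with a plausible range from 25000 nM to 150000 nM, a step of a 1.7-fold lower number from compound 3 to compound 4 (0.22 log units; within the scatter) that may well stay within the scatter.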

Compound 4, half-maximal cytotoxic concentration: 45000 nM
Compound 4: middle estimate off by 1.3-fold (0.12 log units), on the high side; low and high end bracket the measured number.
By their numbers in this assay, from the lowest: compounds 4, 1 and 3 (each within the scatter of the next, the first and the last beyond it).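

In this assay, going by these compounds alone, 4-bromo-2-methylphenyl in place of 4-fluorophenyl gives a 2.2-fold lower number from compound 3 to compound 4 (0.35 log units; beyond the scatter), the first step at this position whose size can be read. It shows that the number does respond to a change of the aromatic group on this carbon of the shared core: the step is modest but lies beyond the scatter, in the direction of higher toxicity in this test. The only earlier step on this group, which ends at compound 3, still cannot be read because compound 2 carries a limit of the assay and not a number: the limit of > 100000 nM in this assay, at which 1 of the 4 values shown sits.

The change from compound 3 to compound 4 swaps fluoro for bromo and adds a methyl in one move, and no compound shown carries only one of these changes, so the share of each in the step stays open. Also open, from the compounds shown here alone, is how the number would respond to an amine or a nitrile on this aromatic ring, and whether the step would hold with a group other than cyclohexylamino on the neighbouring ring atom.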